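Working notes: ethyl extension in the L1210 antiproliferative series

The source may hold more compounds than are shown below. What is called first, only, known or untested is meant among the compounds shown, and "the series" means these compounds.

Compound 1 `Cc1nc(/N=N/N(C)C)c(C(N)=O)[nH]1` gives 3.06 in a functional assay on L1210 cells (Mus musculus) for antiproliferative activity; on this read-out higher numbers stand for higher potency (the scale is a negative logarithm) and lower numbers for lower potency. Compound 2 `CCCCN(C)/N=N/c1n[nH]cc1C(=O)OCC` gives 3.16 and compound 3 `CN(C)/N=N/c1cc(C#N)cc(C#N)c1` gives 2.78; compound 1 thus sits second highest of the three numbers, compound 2 being its nearest neighbour and compound 3 its furthest, with both gaps lying within the scatter of repeated measurements. Compound 4 `CCCc1nc(/N=N/N(C)C)c(C(N)=O)[nH]1` has not yet been measured and differs from compound 1 by ethyl in place of hydrogen on a saturated chain carbon bound to an aromatic carbon. Going by the values given here, no measured pair shows this change, so its direction is untested; the step expected from compound 1 to compound 4 in this assay is a number 0.14 log units higher from compound 1 to compound 4 (within the scatter), small and not clearly beyond the scatter. Compound 4 is estimated at 3.2, within 2.8 to 3.6.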

Compound 4, logarithm of the reciprocal of the active concentration, log(1/C): 3.42
Compound 4: the middle estimate sits 0.22 log units below what was measured; the measured number falls inside the stated range.
By their numbers in this assay, from the lowest: compounds 3, 1, 2 and 4 (each within the scatter of the next, the first and the last beyond it).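

Going by these compounds alone, the first pair at this position shows that ethyl in place of hydrogen on a saturated chain carbon bound to an aromatic carbon raises the number in this assay, with a number 0.36 log units higher from compound 1 to compound 4 (beyond the scatter), a modest step beyond the scatter. On the core of compound 1, the same difference read as methyl to propyl is therefore tolerated without loss of potency. No measurement at hand accounts for the gain. 

As far as these compounds go, whether a longer chain such as butyl would extend the step remains open, as does the outcome with a branched chain or a terminal amine. The compounds shown also leave open whether this change gives a similar step on other cores.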